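Chloro for hydrogen on the carboxyphenyl ring: expected stability

The source may report more compounds than this note shows. Statements on the series, on what has been measured and on what is new or still open speak of the compounds shown alone.

For the measured compounds named here, compound 1 `Cc1c(OCCCCOc2ccc(C(=O)O)cc2)ccc(C(=O)CC(C)C)c1O` is one of three compounds measured in an ADME assay (liver) for metabolic stability, with Liver microsome (Rattus norvegicus) as the target, read by LC-MS, using microsomes and NADPH, with stated times of 5 min and 60 min, tested at 4 uM (on this read-out higher numbers stand for a more stable compound and lower numbers for a less stable compound), where compound 1 gives 66%. Compound 3 `Cc1c(OCCCCOc2ccc(C(=O)O)cc2F)ccc(C(=O)CC2CCCC2)c1O` gives 66%, level with compound 1 within the scatter, so the two together stand highest of the three. Compound 2 `CCC(=O)c1ccc(OCCCCOc2ccc(F)c(C(=O)O)c2)c(C)c1O` gives 35%, a number well beyond the scatter below compound 1. Going by the values given here, no pair of these measured compounds differs in only one place, so no single step is known. Compound 4 `Cc1c(OCCCCOc2ccc(C(=O)O)cc2Cl)ccc(C(=O)CC(C)C)c1O` differs from compound 1 by chloro in place of hydrogen on an aromatic carbon, ortho to a large group and meta to the carboxy group. Among the compounds with values here, with no comparable step to rest on, the expected change from compound 1 to compound 4 is a number 2 percentage points lower from compound 1 to compound 4 (within the scatter), essentially none beyond the scatter. Compound 4 is therefore estimated to give 64%, within a range from 46% to 80%.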

Compound 4, percent of the compound remaining: 61%
The estimate for compound 4 lay 3 percentage points above the measured number, within the range that was stated.
By their numbers in this assay, from the lowest: compound 2; then compounds 4, 1 and 3 (each within the scatter of the next).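

For the compounds shown here, for the first time in this set, a single change can be read on its own: in this assay, chloro in place of hydrogen on an aromatic carbon, ortho to a large group and meta to a carboxy group, gives a number 5 percentage points lower from compound 1 to compound 4 (within the scatter). At this position, then, a chlorine atom leaves the percent remaining without a change beyond the scatter. No measurement offers an explanation of this result.

From the compounds shown here alone, whether a methoxy group or an amine at the same position would read alike remains open. So does whether chloro would give the same step alongside a different ketone side chain.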